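Aryl replacement at the fused core: cytotoxicity notes

The source may hold more compounds than are shown below. What is called first, only, known or untested is meant among the compounds shown, and "the series" means these compounds.

compound 1 `O=c1nc(-c2ccccc2)c2cc(-c3cccnc3)ccc2[nH]1` — > 50000 nM
compound 2 `O=c1nc(-c2ccccc2)c2cc(-c3cccc(F)c3)ccc2[nH]1` — 23000 nM
compound 3 `N#Cc1ccc(-c2ccc3[nH]c(=O)nc(-c4ccccc4)c3c2)cc1` — > 50000 nM

In an ADME assay on L6 cells (Rattus norvegicus) for cytotoxicity, read by fluorescence and resazurin assay, with a stated time of 72 h (a lower number here means that less compound is needed, a higher number that more compound is needed for the effect), compound 1 sits at a limit, > 50000 nM. Compound 3 likewise reaches only a limit in this assay, > 50000 nM. Two of the three values fall there (the limit of > 50000 nM in this assay, at which 2 of the 3 values shown sit). Among the measured compounds shown here, compound 2 is the one value read as a number, 23000 nM. The step of an at least 2.1-fold lower number from compound 1 to compound 2 (0.33 log units; beyond the scatter) and the step of an at least 2.1-fold higher number from compound 2 to compound 3 (0.33 log units; beyond the scatter) are readable only as bounds; the step that the two limits leave unreadable from compound 1 to compound 3 lies between two limits. So compound 3 stands at the limit together with compound 1, while compound 2 sits below it.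

Compound 4, `O=c1nc(-c2ccccc2)c2cc(-c3cncnc3)ccc2[nH]1`, differs from compound 3 by pyrimidin-5-yl in place of 4-cyanophenyl on an aromatic carbon. Pyrimidin-5-yl resembles pyridin-3-yl of compound 1 more than 3-fluorophenyl of compound 2, and both compound 1 and compound 3 rest at the limit. For the measured compounds named here, no measured step carries pyrimidin-5-yl at this position, so the expectation rests on compound 1 and compound 3 alone. Compound 4 is therefore expected to remain at the limit, with an expected step that the limit leaves unreadable from compound 3 to compound 4 not readable beyond the scatter. The estimate for compound 4 is 60000 nM, between 30000 nM and 150000 nM, most likely reported as a limit.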

Compound 4, half-maximal effective concentration: > 50000 nM
Compound 4: a limit, no number (the forecaster's own chance of this, stated with the estimate: 70%); the middle value lies beyond the limit too.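

In this assay compound 4 gives > 50000 nM, which is a limit and not a number. At this carbon of the shared core, pyrimidin-5-yl in place of 3-fluorophenyl gives an at least 2.1-fold higher number from compound 2 to compound 4 (0.33 log units; beyond the scatter), while the steps among compound 1, compound 3 and compound 4 cannot be read. Among the compounds shown here, a second ring with hetero atoms therefore joins pyridin-3-yl and 4-cyanophenyl at the limit, and compound 2 remains the exception as the only compound read as a number: the limit of > 50000 nM in this assay, at which 3 of the 4 values shown sit.

As far as these compounds go, how far compound 1, compound 3 and compound 4 lie from one another stays open. Also open, from the compounds shown here alone, is whether a morpholine, a carboxylic acid or a simple aminomethyl group on this carbon would give a readable number in this assay.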